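Stilbene ethers with basic side chains: electroshock inhibition notes

The source may report more compounds than this note shows. Statements on the series, on what has been measured and on what is new or still open speak of the compounds shown alone.

Compound 1 `COc1ccccc1/C=C/c1ccccc1OCCCCN(C)C` and compound 2 `C(=C/c1ccccc1OCCCCN1CCNCC1)\c1ccccc1` share the same core. In a functional assay on the whole organism with Mus musculus as the target, in the maximal electroshock model, at a dose of 50 mg/kg by the oral route (on this read-out lower numbers stand for less inhibition and higher numbers for more inhibition at the one dose given (going by the name of the read-out)), compound 1 gives 0%. In this assay compound 2 gives 0%, level with compound 1 at the digits shown, within the scatter. Compound 3 `NC(=O)C1CCCN(CCCCOc2ccccc2/C=C/c2ccccc2)C1` differs from compound 2 by 3-carbamoylpiperidin-1-yl in place of piperazin-1-yl on a saturated chain carbon, four bonds along the chain from an oxygen on an aromatic ring. Going by the values given here, no step between measured compounds exists here, so the effect of this change is unknown; in this assay a step of a number 5 percentage points higher from compound 2 to compound 3 (within the scatter) is expected, none beyond the scatter. Compound 3 is estimated at 5%, with a range from 0% to 25%.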

Compound 3, a percentage reported as inhibition, in the whole organism at one dose (the size of the read-out at that dose, not a potency): 0%
Beside the measured number, compound 3's estimate is 5 percentage points above it; the range from low to high includes it.
By their numbers in this assay, from the lowest: compounds 1, 2 and 3 (each within the scatter of the next).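

Placing 3-carbamoylpiperidin-1-yl in place of piperazin-1-yl on a saturated chain carbon, four bonds along the chain from an oxygen on an aromatic ring, gives no change at the digits printed from compound 2 to compound 3 (within the scatter) in this assay. Going by these compounds alone, this is the first step read at this position, and the larger ring group with its added carbonyl does not move the read-out. Nothing available explains this result.

Still open, as far as these compounds go, is whether a morpholin-4-yl group, a carboxylic acid or a longer chain at this place would give any inhibition at all. With no step beyond the scatter, no preference among groups at this position can be stated.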